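The source may hold more compounds than are shown below. What is called first, only, known or untested is meant among the compounds shown, and "the series" means these compounds.

The set rests on a shared core, seen in compound 1 `COc1cccc(-c2c(S(=O)(=O)c3cccc(C#N)c3)cnc3cc(F)ccc23)c1`, compound 2 `N#Cc1cccc(S(=O)(=O)c2cnc3cc(F)ccc3c2-c2cccc(F)c2)c1` and compound 3 `N#Cc1cccc(S(=O)(=O)c2cnc3cc(F)ccc3c2-c2ccccc2F)c1`. In an ADME assay on microsomes from liver (Homo sapiens) for metabolic stability, tested at 2.5 uM (a higher number here means faster removal of the compound, a lower number slower removal), compound 1 gives 1.83 mL/min, compound 2 gives 0.78 mL/min, and compound 3 gives 1.39 mL/min. The step of a 2.3-fold lower number from compound 1 to compound 2 (0.37 log units; beyond the scatter) is the only one among the three that exceeds the scatter; a 1.3-fold lower number from compound 1 to compound 3 (0.12 log units; within the scatter) and a 1.8-fold higher number from compound 2 to compound 3 (0.25 log units; within the scatter) do not, so compound 2 and compound 3 cannot be told apart by these numbers, while compound 2 does stand beyond the scatter from compound 1.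

Compound 4 `COc1ccc(S(=O)(=O)c2cnc3cc(F)ccc3c2-c2cccc(F)c2)cc1Cl` is reached from compound 2 by 3-chloro-4-methoxyphenyl in place of 3-cyanophenyl on a sulfonyl sulfur. For the measured compounds named here, every measured step in this set changes the aryl group on an aromatic carbon of the core; none alters the group on the sulfonyl sulfur, so no measured step bears directly on this change. What the set does show is that its largest step, a 2.3-fold lower number from compound 1 to compound 2 (0.37 log units; beyond the scatter), is modest, and the other two lie within the scatter. Compound 4 is therefore expected to show a step of a 1.7-fold higher number from compound 2 to compound 4 (0.22 log units; within the scatter), small enough that it need not exceed the scatter. The estimate for compound 4 in this assay is 1.3 mL/min, with a range from 0.6 mL/min to 2.8 mL/min.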

Compound 4, intrinsic clearance in a liver preparation (reported as CLH), per the amount of preparation that the assay uses: 2.08 mL/min
Compound 4: the middle estimate sits 1.6-fold (0.20 log units) below what was measured, within the range that was stated.
By their numbers in this assay, from the lowest: compounds 2, 3, 1 and 4 (each within the scatter of the next, the first and the last beyond it).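

In this assay, replacing 3-cyanophenyl with 3-chloro-4-methoxyphenyl on the sulfonyl sulfur, with the 3-fluorophenyl on the aromatic carbon of the shared core unchanged, gives a step beyond the scatter (a 2.7-fold higher number from compound 2 to compound 4 (0.43 log units; beyond the scatter)). For the compounds shown here, this is the first measured step at this position, and it shows that the group on the sulfonyl sulfur can also shift the number, as the aryl group on the aromatic carbon did in the one earlier step beyond the scatter (a 2.3-fold lower number from compound 1 to compound 2 (0.37 log units; beyond the scatter)). No data are at hand to explain the step at the sulfonyl sulfur.

Because the whole aryl group changes at once, the compounds shown do not separate the loss of the nitrile from the entry of the chloro or the methoxy group. They also leave open how this position responds to a different kind of group, such as an amine or a carboxylic acid, and whether the same change gives a similar step with 3-methoxyphenyl or 2-fluorophenyl on the aromatic carbon.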